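Adding a methoxy group to a weak sulfonamide binder

The source may hold more compounds than are shown below. What is called first, only, known or untested is meant among the compounds shown, and "the series" means these compounds.

Compound 2 `N=C(N)c1cccc(CN2CC[C@H](NS(=O)(=O)c3ccc4cccnc4c3)C2=O)c1` was tested in an assay on isolated protein for binding affinity to serine protease 1 (Homo sapiens) (on this read-out lower numbers stand for stronger inhibition and higher numbers for weaker inhibition), where it gives > 2900 nM; this is a limit of the assay, not a measured number. Its near relative compound 1 `N=C(N)c1cccc(CN2CC[C@H](NS(=O)(=O)c3ccc4cnccc4c3)C2=O)c1` also reaches only the limit, giving > 2900 nM in this assay. For the measured compounds named here, the one measured step, a step that the two limits leave unreadable from compound 1 to compound 2, therefore cannot be sized, since both of its ends sit at the limit of > 2900 nM in this assay, at which 2 of the 2 values shown sit. Compound 3 `COc1ccc2ccc(S(=O)(=O)N[C@H]3CCN(Cc4cccc(C(=N)N)c4)C3=O)cc2n1` is not yet measured. It differs from compound 2 by the change (methoxy in place of hydrogen on an aromatic carbon). Going by the values given here, no measured step shows what such a change does, so nothing points to a move beyond the usual scatter in either direction. Compound 3 is expected to remain close to where compound 2 stands, with an estimated step that the limit leaves unreadable from compound 2 to compound 3. The estimate for compound 3 in this assay is 4000 nM, with a range from 1000 nM to 15000 nM, and most likely the assay again reports only a limit.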

Compound 3, inhibition constant: > 2900 nM
Compound 3: no number, only a limit; the forecaster's own chance of this, stated with the estimate: 70%; the middle value does not contradict the limit.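

Compound 3 ends at a limit, as compound 2 does, so no size can be given for the change from hydrogen to methoxy: the limit of > 2900 nM in this assay, at which 3 of the 3 values shown sit.

Left open is how strongly compound 1, compound 2 and compound 3 actually bind, and whether methoxy shifts binding in either direction.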